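The source may report more compounds than this note shows. Statements on the series, on what has been measured and on what is new or still open speak of the compounds shown alone.

Measured so far:
compound 1, `CCS(=O)(=O)Nc1cccc2c1CCCC2c1c[nH]cn1` — 1070 nM in an assay on isolated protein for binding affinity to Alpha-1D adrenergic receptor (Rattus norvegicus), read by radioligand binding; a lower number here means a stronger inhibitor, a higher number a weaker inhibitor
compound 2, `CCS(=O)(=O)Nc1cc(F)cc2c1CCCC2c1c[nH]cn1` — 3630 nM in this assay

Compound 1 gives the lowest number of the two, with compound 2 at a 3.4-fold higher number from compound 1 to compound 2 (0.53 log units; beyond the scatter). Compound 3, `O=C(Nc1cccc2c1CCCC2c1c[nH]cn1)C(F)(F)F`, has not been measured; it differs from compound 1 in this way: (trifluoromethyl)carbonyl in place of ethylsulfonyl on a nitrogen on an aromatic ring. Among the measured compounds shown here, the only measured step swaps hydrogen for fluoro on an aromatic carbon, so it does not bear on this exchange. Going by these compounds, both groups share the ring nitrogen, but what that exchange does here is unknown. Compound 3 is therefore expected to sit near compound 1, estimated at 2000 nM (range 500 nM to 8000 nM), a step of a 1.9-fold higher number from compound 1 to compound 3 (0.27 log units; within the scatter).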

Compound 3, inhibition constant: 3310 nM
Compound 3: the middle estimate sits 1.7-fold (0.22 log units) below what was measured; the range from low to high includes it.
By their numbers in this assay, from the lowest: compound 1; then compounds 3 and 2 (each within the scatter of the next).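

Putting (trifluoromethyl)carbonyl in place of ethylsulfonyl on the nitrogen gives a 3.1-fold higher number from compound 1 to compound 3 (0.49 log units; beyond the scatter) in this assay. Among the compounds shown here, this is the first look at a change on this nitrogen, as the earlier step concerned only an aromatic carbon, and it shows that ethylsulfonyl gives the lower number of these two groups. No measured evidence accounts for this difference.

Going by these compounds, it remains open how a free amine on this nitrogen would compare. Also open, on these data alone, is whether a longer chain on the sulfonyl group, such as propylsulfonyl, would lower the number further.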